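This account rests on a few compounds, and the source may have more. Where it says the series, first, only, none or still open, it means among the compounds named here.

Series notes. Compound 1 `O=S(=O)(/C=C/c1ccccn1)c1cccc(F)c1` and compound 3 `O=S(=O)(/C=C/c1ccccn1)c1ccc(Cl)cc1` share the vinyl sulfone linked to a pyridine; the difference between their two cores is not broken down here. In an assay on U2OS cells for activation of nuclear factor erythroid 2-related factor 2 (Homo sapiens), read by beta-arrestin recruitment, with a stated time of 6 h (on this read-out higher numbers stand for an effect only at larger amounts of compound and lower numbers for an effect already at smaller amounts), compound 1 gives 1680 nM, and in this assay compound 3 gives 1730 nM; these two values lie within the scatter of each other, so no order between compound 1 and compound 3 is read from them.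

Compound 2 `O=S(=O)(/C=C/c1ncccc1F)c1cccc(F)c1` is compound 1 with one change, (fluoro in place of hydrogen on an aromatic carbon). In this assay compound 2 gives 474 nM, which is a 3.5-fold lower number from compound 1 to compound 2 (0.55 log units; beyond the scatter).

Compound 4 `O=S(=O)(/C=C/c1ncccc1F)c1ccc(Cl)cc1` has not yet been measured. It stands to compound 3 as compound 2 stands to compound 1: the change is fluoro in place of hydrogen on an aromatic carbon, and the place of the entering fluoro is described in the same words for both pairs, so this is the same change made on the core of compound 3 instead of the core of compound 1. The change has been seen only once among the measured compounds, so the transfer rests on a single step.

Expectation for compound 4 in this assay: a step of a 3.5-fold lower number from compound 3 to compound 4 (0.54 log units; beyond the scatter) is expected, on the ground that the same change gave a 3.5-fold lower number from compound 1 to compound 2 (0.55 log units; beyond the scatter) and that compound 3, with 1730 nM, starts from a value within the scatter of compound 1. The estimate for compound 4 is therefore 500 nM, with a range of 250 nM to 1000 nM.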

Compound 4, half-maximal effective concentration: 286 nM
Beside the measured number, compound 4's estimate is 1.7-fold (0.24 log units) above it, and the stated range covers the measured number.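

Working notes on the fluoro change. In this assay, fluoro in place of hydrogen on an aromatic carbon, ortho to a large group and two atoms from the ring nitrogen, gives a 6.0-fold lower number from compound 3 to compound 4 (0.78 log units; beyond the scatter), so the step seen on the core of compound 1 appears in the same direction on the core of compound 3. Going by these compounds alone, the two steps are of one size as far as these data can tell, and the series so far supports carrying the change across these cores: the same change on two cores in this assay, a 3.5-fold lower number (0.55 log units; beyond the scatter) from compound 1 to compound 2 and a 6.0-fold lower number (0.78 log units; beyond the scatter) from compound 3 to compound 4, 1.7-fold (0.23 log units) apart, within the scatter of two such steps This rests on one pair per core and on two closely related cores only, so it does not show that the change would carry to any other core, and it gives no ground for reading the apparent gap between the steps as an effect of the core or for naming a cause of the step.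

The compounds shown leave open whether the step depends on fluoro itself, or whether a methyl, a methoxy or an amine at the same place would give a similar step. Also open, going by these compounds, is whether the step survives on a core where the halogen of the other aromatic ring gives way to a carboxylic acid or a longer chain.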